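The compounds below may be only part of what the source reports. "The series", "measured", "known", "first", "only" and "open" are said of these compounds alone.

Measured so far in a functional assay on SK-BR-3 cells (Homo sapiens) for antiproliferative activity, read by MTT assay, with a stated time of 72 h; on this read-out higher numbers stand for weaker inhibition and lower numbers for stronger inhibition:

compound 1, `C/C=C1/[C@H](O[C@@H]2O[C@H](CO)[C@@H](O)[C@H](O)[C@H]2O)OC=C(C(=O)OC)[C@H]1CC(=O)NCCC` — > 20000 nM
compound 2, `C=CCOC(=O)C[C@@H]1C(C(=O)OC)=CO[C@@H](O[C@@H]2O[C@H](COC(C)=O)[C@@H](OC(C)=O)[C@H](OC(C)=O)[C@H]2OC(C)=O)/C1=C/C` — > 20000 nM
compound 3, `C/C=C1/[C@H](O[C@@H]2O[C@H](COC(C)=O)[C@@H](OC(C)=O)[C@H](OC(C)=O)[C@H]2OC(C)=O)OC=C(C(=O)OC)[C@H]1CC(=O)OCCC(C)C` — > 15000 nM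

Every value in this assay is a limit of the assay and not a number. For compound 1 the value > 20000 nM is such a limit. For compound 2 the value > 20000 nM is such a limit. For compound 3 the value > 15000 nM is such a limit. Compound 1 therefore sits at the limit of > 20000 nM in this assay, at which 2 of the 3 values shown sit, the position shared with compound 2. Compound 3 sits at the limit of > 15000 nM in this assay, at which 1 of the 3 values shown sits. Within the data shown here, the only single-point step between measured compounds is a step that the two limits leave unreadable from compound 2 to compound 3; it gives no readable size and so cannot guide the change below.

Compound 4, `C/C=C1/[C@H](O[C@@H]2O[C@H](CO)[C@@H](O)[C@H](O)[C@H]2O)OC=C(C(=O)OC)[C@H]1CC(=O)OCCc1ccc(OC)cc1`, differs from compound 1 by 2-(4-methoxyphenyl)ethoxy in place of propylamino on a carbonyl carbon. Among the measured compounds shown here, no measured step bears on this change, and no line of the series gives a direction for it. With all three measured compounds at a limit, compound 4 is expected to fall near the same region, most likely again as a limit rather than a number: the estimate for compound 4 is 25000 nM, with a range of 8000 nM to 60000 nM. The expected step is a step that the limit leaves unreadable from compound 1 to compound 4, which is not separable from the scatter.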

Compound 4, half-maximal inhibitory concentration: > 20000 nM
Compound 4 was reported as a limit; the forecaster's own chance of this, stated with the estimate: 70%; the middle value does not contradict the limit.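

Compound 4 gives > 20000 nM, which is a limit of the assay and not a number. With compound 1 also at a limit, the pair yields no readable step. The compounds shown leave open whether any group on this carbonyl carbon gives a measured number rather than a limit.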